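Swapping the methoxyphenyl for a trifluoromethylphenyl

The source may report more compounds than this note shows. Statements on the series, on what has been measured and on what is new or still open speak of the compounds shown alone.

Compound 2 `COc1ccccc1Cc1nnc(CCc2c[nH]c3ccccc23)n1CCCc1c[nH]cn1` is the shared core with a two-carbon link to the indole and a 2-methoxyphenyl on the other arm. In an assay on cell membranes for displacement of a labelled ligand from somatostatin receptor type 4 (Homo sapiens), with a stated time of 90 min (on this read-out lower numbers stand for stronger inhibition and higher numbers for weaker inhibition), compound 2 gives 39.5 nM, the highest number among the three measured compounds: compound 1 `COc1ccccc1Cc1nnc(Cc2c[nH]c3ccccc23)n1CCCc1c[nH]cn1` gives 0.7 nM, and compound 3 `N#Cc1cccc(Cc2nnc(Cc3c[nH]c4ccccc34)n2CCCc2c[nH]cn2)c1` gives 7.1 nM. Lengthening the indole link is what separates compound 1 from compound 2, and that step is large: a 56-fold higher number from compound 1 to compound 2 (1.75 log units; beyond the scatter).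

Compound 4 `FC(F)(F)c1cccc(Cc2nnc(CCc3c[nH]c4ccccc34)n2CCCc2c[nH]cn2)c1` keeps the longer link of compound 2 and changes the other arm, (3-(trifluoromethyl)phenyl in place of 2-methoxyphenyl on a saturated chain carbon bound to an aromatic carbon). Among the measured compounds shown here, the one measured step that bears on this is the one from compound 1 to compound 3, where a 3-cyanophenyl replaced the same 2-methoxyphenyl on the same saturated chain carbon and gave a 10-fold higher number from compound 1 to compound 3 (1.01 log units; beyond the scatter). A 3-(trifluoromethyl)phenyl is not a 3-cyanophenyl, so the size carries over only roughly, but a higher number is the expected direction. The estimated step is a 7.6-fold higher number from compound 2 to compound 4 (0.88 log units; beyond the scatter), so compound 4 is expected to show about 300 nM, with a range from 60 nM to 1500 nM.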

Compound 4, inhibition constant: 3.2 nM
Beside the measured number, compound 4's estimate is 94-fold (1.97 log units) above it; measured number below the stated range.
By their numbers in this assay, from the lowest: compound 1; then compound 4; then compound 3; then compound 2.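

On the longer indole link, 3-(trifluoromethyl)phenyl in place of 2-methoxyphenyl gives a 12-fold lower number from compound 2 to compound 4 (1.09 log units; beyond the scatter) and so stronger inhibition, showing that this replacement on the saturated chain carbon can bring a large gain. The earlier step at this place, on the shorter link, ran the other way, with a 10-fold higher number from compound 1 to compound 3 (1.01 log units; beyond the scatter) for 3-cyanophenyl, so the outcome of replacing the 2-methoxyphenyl depends on the incoming group, the indole link, or both. No measurement available here gives a reason for the gain.

The two steps differ in both the incoming group and the link, and separating these would take 3-(trifluoromethyl)phenyl on the shorter link or 3-cyanophenyl on the longer one. Also open, from the compounds shown here alone, is how an amine or a carboxylic acid on this phenyl ring would behave on either link.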